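Amino for hydrogen on the core of compound 2

The source may hold more compounds than are shown below. What is called first, only, known or untested is meant among the compounds shown, and "the series" means these compounds.

Three compounds share the fused core with the chloromethyl-substituted benzyl group. Compound 1 `ClCc1ccccc1Cn1cnc2c(Cl)nc(Cl)nc21` gives 3630 nM in a functional assay on HOP-62 cells (Homo sapiens) for cytotoxicity, read by sulforhodamine B assay, with a stated time of 48 h; on this read-out lower numbers stand for stronger inhibition of growth and higher numbers for weaker inhibition of growth. Compound 2 `ClCc1ccccc1Cn1cnc2c(Cl)ncnc21` gives 6020 nM in this assay, and compound 3 `ClCc1ccc(Cn2cnc3nc(Cl)nc(Cl)c32)cc1` gives 3890 nM. Compound 2 stands at the upper end of the three numbers shown, yet its gap to compound 3 is within the scatter, and the one single-point step known, a 1.7-fold higher number from compound 1 to compound 2 (0.22 log units; within the scatter), is within the scatter as well.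

Compound 4 `Nc1nc(Cl)c2ncn(Cc3ccccc3CCl)c2n1` is the next member: amino in place of hydrogen on an aromatic carbon. The change sits on the same aromatic carbon that the step from compound 1 to compound 2 touched, so that step is the only one that bears on it, and it was small. Within the data shown here, no measured step involves an amino group, so the direction is open. The expectation is therefore for a step of a 1.2-fold lower number from compound 2 to compound 4 (0.08 log units; within the scatter) in this assay, with nothing beyond the scatter. For compound 4 the estimated value is 5000 nM, with a range from 1800 nM to 14000 nM.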

Compound 4, concentration for total growth inhibition: 61700 nM
For compound 4 the middle estimate is 12-fold (1.09 log units) below the measured one; the measured number lies above the stated range.
By their numbers in this assay, from the lowest: compounds 1, 3 and 2 (each within the scatter of the next); then compound 4.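

In this assay, the aromatic carbon between two ring nitrogen atoms proves sensitive to the group it carries: a 10-fold higher number from compound 2 to compound 4 (1.01 log units; beyond the scatter) for amino in place of hydrogen, whereas chloro and hydrogen at this carbon stay within the scatter (a 1.7-fold higher number from compound 1 to compound 2 (0.22 log units; within the scatter)). Amino in place of chloro gives the same direction, a 17-fold higher number from compound 1 to compound 4 (1.23 log units; beyond the scatter), so among the three groups seen here, amino alone stands apart, with weaker inhibition of growth. Nothing available explains why this change weakens growth inhibition so strongly.

As far as these compounds go, it remains open whether the weakening is particular to amino or also follows from other groups on this carbon, such as methylamino, hydroxyl or methyl. Also open, from the compounds shown here alone, is whether amino has the same effect when the chloromethyl group sits as in compound 3.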